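Replacing 3-chlorophenyl with bromo: what to expect

The compounds below may be only part of what the source reports. "The series", "measured", "known", "first", "only" and "open" are said of these compounds alone.

Of the compounds shown here, three sharing one core have been measured in a physicochemical assay for lipophilicity, read by HPLC, at pH 7.5; on this read-out lower numbers stand for lower lipophilicity and higher numbers for higher lipophilicity. Compound 1 `CC[C@@H](Nc1c(C#N)c(-c2ccc(-c3cccc(C)c3F)cc2)nc2cnccc12)C(N)=O` gives 3, compound 2 `CC[C@@H](Nc1c(C#N)c(-c2ccc(-c3ccccc3N(C)C)cc2)nc2cnccc12)C(N)=O` gives 3.2, and compound 3 `CC[C@@H](Nc1c(C#N)c(-c2ccc(-c3cccc(Cl)c3)cc2)nc2cnccc12)C(N)=O` gives 3.1. Compound 3 therefore stands within the scatter of both others, and the three cannot be told apart on these numbers. The measured steps are a number 0.20 log units higher from compound 1 to compound 2 (within the scatter), a number 0.10 log units higher from compound 1 to compound 3 (within the scatter) and a number 0.10 log units lower from compound 2 to compound 3 (within the scatter).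

Compound 4 `CC[C@@H](Nc1c(C#N)c(-c2ccc(Br)cc2)nc2cnccc12)C(N)=O` departs from compound 3 in a different way: bromo in place of 3-chlorophenyl on an aromatic carbon. This exchange sits para to a large group. Each measured step exchanges one substituted phenyl for another, and none removes a ring, so these small steps set no size for this change. Going by the values given here, the data hold no direct precedent for it. Resting on the number of heavy atoms that leave, the expected step is a number 0.50 log units lower from compound 3 to compound 4 (beyond the scatter). Compound 4 is estimated at 2.6, with an expected range from 2.1 to 3.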

Compound 4, distribution coefficient: 2.2
Compound 4: middle estimate off by 0.40 log units, on the high side; the measured number falls inside the stated range.
By their numbers in this assay, from the lowest: compound 4; then compounds 1, 3 and 2 (each within the scatter of the next).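

In this assay, going by these compounds alone, the exchange at this place, para to a large group, produces the first steps beyond the scatter (a number 0.90 log units lower from compound 3 to compound 4 (beyond the scatter); a number 1.00 log units lower from compound 2 to compound 4 (beyond the scatter); a number 0.80 log units lower from compound 1 to compound 4 (beyond the scatter)). The earlier exchanges of one substituted phenyl for another left the numbers within the scatter of each other, whereas all three compounds that carry a substituted phenyl here stand apart from compound 4, which carries bromo. Nothing in the data shown accounts for the size of these steps.

The compounds shown leave open how much of the step goes with the departing phenyl ring and how much with bromo itself. They also leave open whether a chloro group, an amine or a saturated carbon ring such as cyclohexyl in this place would fall near compound 4 or near the compounds that carry a phenyl ring.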